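A few compounds are considered here, and "the series" means these few. Any claim that something is new, unique, unknown or untested is made for them only; others in the source may bear on it.

Of the compounds shown here, two have so far been measured in a physicochemical assay for lipophilicity, read by HPLC, in phosphate buffer, measured as chromatographic lipophilicity, at pH 7.4; on this read-out lower numbers stand for lower lipophilicity and higher numbers for higher lipophilicity. Compound 1 `COc1ccc2nc(C)cc(OCCNc3cc(C)cc(C)c3)c2c1` gives 6.93 in this assay, while compound 2 `COc1ccc(NC(=O)COc2cc(C)nc3ccc(OC)cc23)cc1` gives 4.22. Compound 2 therefore stands lowest of the two numbers, and the gap to compound 1 is well beyond the usual scatter of the method. For the measured compounds named here, since compound 1 and compound 2 differ in several places at once, no single structural step between them can be read from these two values alone.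

Compound 3 `COc1ccc2nc(C)cc(OCC(=O)Nc3cccnc3)c2c1` has not yet been measured. It differs from compound 2 in one place: pyridin-3-yl in place of 4-methoxyphenyl on an amide-type nitrogen. The pyridin-3-yl group replaces the 4-methoxyphenyl group on the amide-type nitrogen, and the rest of the shared core stays as it is.

Going by the values given here, no measured pair in this set shows exactly this exchange, so the expected step has to be an estimate. The step from compound 2 to compound 3 in this assay is expected to be a clear fall of about a number 1.22 log units lower from compound 2 to compound 3 (beyond the scatter), beyond the scatter. On that basis compound 3 is estimated to give 3 in this assay, most likely between 2.4 and 3.6.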

Compound 3, distribution coefficient: 2.46
Compound 3: the middle estimate sits 0.54 log units above what was measured; measured number inside the range.
By their numbers in this assay, from the lowest: compound 3; then compound 2; then compound 1.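

For the compounds shown here, this is the first step in the set that can be read at a single place: with the shared core unchanged, pyridin-3-yl in place of 4-methoxyphenyl on an amide-type nitrogen gives a number 1.76 log units lower from compound 2 to compound 3 (beyond the scatter) in this assay. The group on this nitrogen can therefore move the read-out by itself, beyond the scatter, which the comparison of compound 1 with compound 2 could not show, as those two differ in several places at once. The exchange alters more than one feature, going from 8 heavy atoms to 6 and from a ring of carbon only to a ring with 1 hetero atom, and nothing available explains the size of the fall.

As far as these compounds go, how much of the step goes with the ring nitrogen and how much with the methoxy group remains open, and a plain phenyl group on the same nitrogen would help to separate the two. Pyridin-2-yl and pyridin-4-yl would show whether the place of the ring nitrogen matters as well.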